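A few compounds are considered here, and "the series" means these few. Any claim that something is new, unique, unknown or untested is made for them only; others in the source may bear on it.

Three amides built on the same stilbene-like core have been measured. Compound 1 `COc1ccc(/C=C/c2cc(OC)cc(OC)c2/C=C/C(=O)N2CCCCC2C)cc1` gives 4350 nM in a functional assay on MCF7 cells (Homo sapiens) for inhibition, read by MTT assay, with a stated time of 48 h; on this read-out higher numbers stand for weaker inhibition and lower numbers for stronger inhibition. Compound 2 `C#CCNC(=O)/C=C/c1c(/C=C/c2ccc(OC)cc2)cc(OC)cc1OC` gives 4560 nM, and compound 3 `COc1ccc(/C=C/c2cc(OC)cc(OC)c2/C=C/C(=O)N2CCC(c3ccccc3)CC2)cc1` gives 4230 nM. Compound 3 carries the lowest of the three numbers, but its nearest neighbour is compound 1 with a 1.0-fold lower number from compound 1 to compound 3 (0.01 log units; within the scatter), and compound 2 differs by a 1.1-fold lower number from compound 2 to compound 3 (0.03 log units; within the scatter), so all three sit together within the usual scatter. The step from compound 1 to compound 2, a 1.0-fold higher number from compound 1 to compound 2 (0.02 log units; within the scatter), tells the same story: swapping the group on the carbonyl carbon among a 2-methylpiperidin-1-yl, a propargylamino and a 4-phenylpiperidin-1-yl changed nothing measurable.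

Compound 4 `CCCCCCNC(=O)/C=C/c1c(/C=C/c2ccc(OC)cc2)cc(OC)cc1OC` makes one further swap at the same place: hexylamino in place of 4-phenylpiperidin-1-yl on a carbonyl carbon. Every earlier exchange at this carbonyl carbon stayed within the scatter, so no step beyond it is expected here either. The value of compound 4 in this assay is estimated at 4400 nM, with a range from 2000 nM to 10000 nM. This expectation corresponds to a step of a 1.0-fold higher number from compound 3 to compound 4 (0.02 log units; within the scatter) from compound 3 to compound 4.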

Compound 4, half-maximal inhibitory concentration: 5530 nM
Beside the measured number, compound 4's estimate is 1.3-fold (0.10 log units) below it; the range from low to high includes it.
By their numbers in this assay, from the lowest: compounds 3, 1, 2 and 4 (each within the scatter of the next).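

Even an exchange that removes both rings of the 4-phenylpiperidin-1-yl group and brings in an open hexylamino chain with an amide hydrogen leaves the reading in this assay within the scatter (a 1.3-fold higher number from compound 3 to compound 4 (0.12 log units; within the scatter)). The same holds against the other two amides (a 1.3-fold higher number from compound 1 to compound 4 (0.10 log units; within the scatter); a 1.2-fold higher number from compound 2 to compound 4 (0.08 log units; within the scatter)), including the pentyl-for-ethynyl exchange at the end of the chain. Across these four compounds, then, neither a ring nor an amide hydrogen on the group at this carbonyl carbon separates the readings.

Still open, going by these compounds, is whether a carboxylic acid or a dimethylamino group on the chain at this carbonyl carbon would give a step beyond the scatter. No supporting measurement bears on why these four amides read alike.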